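Swapping the aryl group on the urea nitrogen

This account rests on a few compounds, and the source may have more. Where it says the series, first, only, none or still open, it means among the compounds named here.

Measured so far in a functional assay on RS4-11 cells (Homo sapiens) for inhibition, read by CCK-8 assay, with a stated time of 48 h; a lower number here means a stronger inhibitor, a higher number a weaker inhibitor:
compound 1 `O=C(NCCNS(=O)(=O)c1ccc(-c2ccccc2Oc2ccc([N+](=O)[O-])c([N+](=O)[O-])c2)s1)Nc1cc(Cl)cc(Cl)c1` — 2100 nM
compound 2 `O=C(NCCNS(=O)(=O)c1ccc(-c2ccccc2Oc2ccc([N+](=O)[O-])c([N+](=O)[O-])c2)s1)Nc1ccc(Cl)cc1` — 6700 nM
compound 3 `Cc1cc(C)cc(NC(=O)NCCNS(=O)(=O)c2ccc(-c3ccccc3Oc3ccc([N+](=O)[O-])c([N+](=O)[O-])c3)s2)c1` — 3600 nM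

Compound 3 gives the second highest of these three numbers; its neighbours sit close on either side, with a 1.7-fold higher number from compound 1 to compound 3 (0.23 log units; within the scatter) and a 1.9-fold lower number from compound 2 to compound 3 (0.27 log units; within the scatter), both within the scatter. Compound 4 `COc1ccc(NC(=O)NCCNS(=O)(=O)c2ccc(-c3ccccc3Oc3ccc([N+](=O)[O-])c([N+](=O)[O-])c3)s2)cc1` is the next compound in this series, and it differs from compound 3 at one place: 4-methoxyphenyl in place of 3,5-dimethylphenyl on an amide-type nitrogen.

Among the compounds with values here, two measured steps bear on this change. Both of them also alter the aryl group on the amide-type nitrogen. The step of a 3.2-fold higher number from compound 1 to compound 2 (0.50 log units; beyond the scatter) shows that replacing a 3,5-disubstituted phenyl by a 4-substituted one can weaken inhibition beyond the scatter. The step of a 1.9-fold lower number from compound 2 to compound 3 (0.27 log units; within the scatter), running the other way, stays within the scatter. Taken together they suggest that a move from a 3,5-disubstituted to a 4-substituted phenyl tends to raise the number in this assay modestly, though only one such step lies beyond the scatter.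

For compound 4 a modestly higher number than compound 3 is therefore expected, namely a 1.9-fold higher number from compound 3 to compound 4 (0.29 log units; within the scatter). The estimated value for compound 4 in this assay is 7000 nM, with a likely range from 3000 nM to 16000 nM.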

Compound 4, half-maximal inhibitory concentration: 1400 nM
Beside the measured number, compound 4's estimate is 5.0-fold (0.70 log units) above it; the whole stated range lies above it.
By their numbers in this assay, from the lowest: compounds 4, 1, 3 and 2 (each within the scatter of the next, the first and the last beyond it).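

In this assay, methoxy in place of chloro on an aromatic carbon gives a 4.8-fold lower number from compound 2 to compound 4 (0.68 log units; beyond the scatter) with the rest of the structure unchanged, showing that the group carried by a 4-substituted phenyl on this urea nitrogen can by itself shift the number beyond the scatter. The earlier suggestion that a 4-substituted phenyl does worse than a 3,5-disubstituted one therefore rests on compound 2 alone: 4-methoxyphenyl in place of 3,5-dimethylphenyl gives a 2.6-fold lower number from compound 3 to compound 4 (0.41 log units; beyond the scatter) and goes against it, and 4-methoxyphenyl in place of 3,5-dichlorophenyl gives a 1.5-fold lower number from compound 1 to compound 4 (0.18 log units; within the scatter) and stays within the scatter, so compound 4 and compound 1 cannot be told apart. Nothing measured on these groups speaks to why methoxy differs from chloro here.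

On these data alone, with a single methoxy example, it remains open whether 4-hydroxyphenyl, 4-aminophenyl or 4-carboxyphenyl on the same nitrogen would follow compound 4 or compound 2. As far as these compounds go, it is also open whether 3,5-dimethoxyphenyl would add to the effect, and whether an aromatic ring is needed here at all, as a cyclohexyl group would test.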